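The source may hold more compounds than are shown below. What is called first, only, known or untested is meant among the compounds shown, and "the series" means these compounds.

Working notes on the series. Compound 1 `Cc1cccnc1-c1ccc(C(=O)Nc2ccc(Cl)cc2)cc1` gives 1500 nM in a functional assay for antagonist activity at transient receptor potential cation channel subfamily V member 1 (Homo sapiens), read by FLIPR; on this read-out lower numbers stand for stronger inhibition and higher numbers for weaker inhibition. Compound 2 `Cc1cccnc1-c1ccc(C(=O)Nc2ccc(C(F)(F)F)cc2)cc1` gives 65 nM in this assay, the step being a 23-fold lower number from compound 1 to compound 2 (1.36 log units; beyond the scatter). Compound 3 `Cc1cccnc1-c1ccc(C(=O)Nc2ccc(C(C)(C)C)cc2)cc1` gives 11 nM in this assay, with a 140-fold lower number from compound 1 to compound 3 (2.13 log units; beyond the scatter) and a 5.9-fold lower number from compound 2 to compound 3 (0.77 log units; beyond the scatter); compound 3 therefore stands lowest of the three measured numbers, both of its steps beyond the scatter.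

Compound 4 `CC(C)(C)c1ccc(NC(=O)c2ccc(-c3ncccc3C#N)cc2)cc1` differs from compound 3 by cyano in place of methyl on an aromatic carbon. Among the compounds with values here, none of the measured steps bears on this change: all three exchange the group at the other position, the one carrying chloro, trifluoromethyl or tert-butyl, so the direction here is unsupported by data. The step from compound 3 to compound 4 is expected to be small, a 1.8-fold higher number from compound 3 to compound 4 (0.26 log units; within the scatter). Compound 4 is estimated at 20 nM in this assay, range 5 nM to 80 nM.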

Compound 4, half-maximal inhibitory concentration: 30 nM
Compound 4: the middle estimate sits 1.5-fold (0.18 log units) below what was measured; the range from low to high includes it.
By their numbers in this assay, from the lowest: compound 3; then compound 4; then compound 2; then compound 1.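

Cyano in place of methyl gives the first reading at this position in this assay, with a 2.7-fold higher number from compound 3 to compound 4 (0.44 log units; beyond the scatter) and tert-butyl kept at the other position. The position therefore responds to this exchange, though the step is only modest and the nitrile keeps a measurable inhibition in the same series. No measured data on the compounds account for this shift.

As far as these compounds go, whether the step holds with trifluoromethyl or chloro at the other position stays open. From the compounds shown here alone, how an amine, a methoxy group or a longer chain such as ethyl would read at this position also stays open.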